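Piperazine nitrogen substituent series: estimate for compound 4

The source may report more compounds than this note shows. Statements on the series, on what has been measured and on what is new or still open speak of the compounds shown alone.

Measured so far in an assay for inhibition of proto-oncogene tyrosine-protein kinase receptor Ret (Homo sapiens), read by 33P incorporation, in the presence of a further agent that is not named here; on this read-out lower numbers stand for stronger inhibition and higher numbers for weaker inhibition:
Compound 1 `CNc1ncc2c(-c3ccc(N4CCNCC4)nc3)nn(Cc3cn(Cc4ccccc4)nn3)c2n1` gives 600 nM.
Compound 2 `CNc1ncc2c(-c3ccc(N4CCN(C)CC4)nc3)nn(Cc3cn(Cc4ccccc4)nn3)c2n1` gives 900 nM.
Compound 3 `CCN1CCN(c2ccc(-c3nn(Cc4cn(Cc5ccccc5)nn4)c4nc(NC)ncc34)cn2)CC1` gives 6200 nM.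

Compound 3 stands with the highest number of the three measured. The two steps that lead onto it are a 10-fold higher number from compound 1 to compound 3 (1.01 log units; beyond the scatter) and a 6.9-fold higher number from compound 2 to compound 3 (0.84 log units; beyond the scatter), whereas a 1.5-fold higher number from compound 1 to compound 2 (0.18 log units; within the scatter).

Compound 4 `CNc1ncc2c(-c3ccc(N4CCN(C(=O)C(C)(C)C)CC4)nc3)nn(Cc3cn(Cc4ccccc4)nn3)c2n1` differs from compound 3 by (tert-butyl)carbonyl in place of ethyl on an amine nitrogen in a ring. Going by the values given here, the steps that bear on this change are the two onto compound 3: each enlarged the group on the same amine nitrogen in the ring, and each gave a higher number in this assay. Among the compounds with values here, the entering (tert-butyl)carbonyl is larger again and brings one hydrogen-bond acceptor; no measured step covers an acyl group on that nitrogen, so the direction rests only on the size trend seen in compounds 1, 2 and 3. Compound 4 is therefore expected to give a higher number than compound 3, by a 1.6-fold higher number from compound 3 to compound 4 (0.21 log units; within the scatter). The estimate for compound 4 in this assay is 10000 nM, with a range from 2500 nM to 40000 nM.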

Compound 4, half-maximal inhibitory concentration: 4000 nM
For compound 4 the middle estimate is 2.5-fold (0.40 log units) above the measured one; low and high end bracket the measured number.
By their numbers in this assay, from the lowest: compounds 1 and 2 (each within the scatter of the next); then compounds 4 and 3 (each within the scatter of the next).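

In this assay, (tert-butyl)carbonyl on the amine nitrogen in the ring does not separate from ethyl (a 1.6-fold lower number from compound 3 to compound 4 (0.19 log units; within the scatter)), so the rise with group size seen across compounds 1, 2 and 3 does not carry through to compound 4, which goes against it. The acyl compound still stands apart from the two compounds with the smallest groups (a 4.4-fold higher number from compound 2 to compound 4 (0.65 log units; beyond the scatter); a 6.7-fold higher number from compound 1 to compound 4 (0.82 log units; beyond the scatter)), leaving hydrogen and methyl as the only substituents at the low end of the series. No evidence at hand bears on this result.

From the compounds shown here alone, whether acetyl, a smaller acyl group, on this nitrogen would fall nearer compound 1 or nearer compound 4 stays open. So does the standing of a longer chain such as propyl, or of a chain ending in a carboxylic acid.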